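The source may report more compounds than this note shows. Statements on the series, on what has been measured and on what is new or still open speak of the compounds shown alone.

Measured in an in vitro assay on HEK385-7 cells for displacement of a labelled ligand from prostaglandin D2 receptor 2 (Homo sapiens); on this read-out lower numbers stand for stronger inhibition and higher numbers for weaker inhibition:
compound 1, `O=C(O)Cc1sc(C(c2ccccc2)c2ccc(O)cc2)nc1-c1ccc(F)cc1`, gives 3.4 nM
compound 2, `NS(=O)(=O)c1ccc(-c2nc(C(c3ccc(F)cc3)c3ccc(F)cc3)sc2CC(=O)O)cc1`, gives 1500 nM

Compound 2 stands at the highest of the two numbers in this assay; its nearest neighbour, compound 1, gives 3.4 nM, a far lower number, and the gap between the two lies well beyond the scatter. For the measured compounds named here, no step between compounds that differ in one place has been measured, so the pair shows only that a large difference in the group carried on the shared core goes with a large difference in this assay.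

Compound 3, `Nc1cc(-c2nc(C(c3ccc(F)cc3)c3ccc(F)cc3)sc2CC(=O)O)cc(F)n1`, is yet to be measured. It differs from compound 2 in one place: 2-amino-6-fluoropyridin-4-yl in place of 4-sulfamoylphenyl on an aromatic carbon. Going by the values given here, with no measured single step to lean on, the direction of this change is uncertain; the step of a 2.5-fold lower number from compound 2 to compound 3 (0.40 log units; beyond the scatter) is expected to be a moderate lowering, not certainly beyond the scatter. Compound 3 is estimated at 600 nM, within a wide range from 100 nM to 3000 nM.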

Compound 3, half-maximal inhibitory concentration: 220 nM
Compound 3: middle estimate off by 2.7-fold (0.44 log units), on the high side; low and high end bracket the measured number.
By their numbers in this assay, from the lowest: compound 1; then compound 3; then compound 2.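

Replacing 4-sulfamoylphenyl with 2-amino-6-fluoropyridin-4-yl on the aromatic carbon next to the ring nitrogen gives, in this assay, a 6.8-fold lower number from compound 2 to compound 3 (0.83 log units; beyond the scatter), so with the rest of the molecule unchanged, the number responds to the group at this position alone. The leaving and entering groups have the same counts of hydrogen-bond donors and acceptors and no net charge, so these counts do not distinguish them, while the ring hetero atom and the heavy-atom make-up do differ. Nothing available explains why the step occurs.

The compounds shown do not separate the contributions of the amine, the fluorine and the ring nitrogen of the entering group. Also open, on these data alone, is where an unsubstituted pyridine, or a phenyl ring carrying a carboxamide, would stand at this position.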